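A few compounds are considered here, and "the series" means these few. Any claim that something is new, unique, unknown or untested is made for them only; others in the source may bear on it.

Measured in a functional assay on CHO-K1 cells for agonist activity at Glucose-dependent insulinotropic receptor (Homo sapiens), read by a luciferase reporter, with a stated time of 5 h; on this read-out higher numbers stand for an effect only at larger amounts of compound and lower numbers for an effect already at smaller amounts:
compound 1 `CCCS(=O)(=O)N1CCN(c2ccc(OCC3CCN(C(=O)NC(C)C)CC3)cn2)CC1` gives 1000 nM
compound 2 `CCCS(=O)(=O)N1CCN(c2ccc(OCC3CCN(C(=O)C(F)F)CC3)cn2)CC1` gives 2100 nM
compound 3 `CCCS(=O)(=O)N1CCN(c2ccc(OCC3CCN(C(=O)N4CCOCC4)CC3)cn2)CC1` gives > 10000 nM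

Compound 3 stands only at a limit of this assay, > 10000 nM, and no number is known for it. This is the limit of > 10000 nM in this assay, at which 1 of the 3 values shown sits. Compound 4 `CCCS(=O)(=O)N1CCN(c2ccc(OCC3CCN(C(=O)Nc4ccc(C(C)C)cc4)CC3)cn2)CC1` is the next step: (4-isopropylphenyl)amino in place of morpholin-4-yl on a carbonyl carbon. Among the measured compounds shown here, two measured steps bear on it, both ending at compound 3: an at least 10-fold higher number from compound 1 to compound 3 (1.00 log units; beyond the scatter) and an at least 4.7-fold higher number from compound 2 to compound 3 (0.67 log units; beyond the scatter). In both, the move to morpholin-4-yl on the carbonyl carbon raised the number beyond the scatter. Compound 4 again carries an amino group on that carbonyl carbon, as compound 1 does with isopropylamino, and compound 1 gives 1000 nM. Read in reverse, the step from compound 1 to compound 3 suggests that leaving morpholin-4-yl should lower the number in this assay, though no measured compound carries an aryl amino group here, so the size is uncertain and a limit remains possible. The expected step is an at least 4.0-fold lower number from compound 3 to compound 4 (0.60 log units; beyond the scatter). Compound 4 is estimated at 2500 nM, within 600 nM to 10000 nM.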

Compound 4, half-maximal effective concentration: 900 nM
Compound 4: middle estimate off by 2.8-fold (0.44 log units), on the high side, and the stated range covers the measured number.
By their numbers in this assay, from the lowest: compounds 4 and 1 (each within the scatter of the next); then compound 2. At a limit, above all of these: compound 3.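

In this assay, (4-isopropylphenyl)amino on the carbonyl carbon recovers the response absent with morpholin-4-yl, with an at least 11-fold lower number from compound 3 to compound 4 (1.04 log units; beyond the scatter), and it also improves on difluoromethyl, with a 2.3-fold lower number from compound 2 to compound 4 (0.37 log units; beyond the scatter). The amide-type nitrogen accepts an aromatic ring as readily as a small branched chain, with a 1.1-fold lower number from compound 1 to compound 4 (0.05 log units; within the scatter), so exchanging isopropyl for 4-isopropylphenyl there gives no separation on this read-out. The value of compound 3 is a limit and not a number, so the step from it gives only a bound: the limit of > 10000 nM in this assay, at which 1 of the 4 values shown sits.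

Dimethylamino on the carbonyl carbon would show whether the amide hydrogen matters apart from the morpholine ring, as it lacks that hydrogen but has no such ring. Plain phenylamino would show whether the isopropyl on the aromatic ring contributes anything to the value.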